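A few compounds are considered here, and "the series" means these few. Any claim that something is new, unique, unknown or untested is made for them only; others in the source may bear on it.

Working notes on a thiourea-type series built on a shared core. Compound 1 `Fc1ccccc1NC(=S)Nc1cccc(C(F)(F)F)c1`, compound 2 `CCCCc1ccc(NC(=S)Nc2cccc(C(F)(F)F)c2)c(C)c1` and compound 3 `O=C(NC(=S)Nc1cccc(C(F)(F)F)c1)[C@H]1C[C@@H]2CC[C@H]1C2` have been run in an ADME assay on Vero 76 cells (Chlorocebus sabaeus) for cytotoxicity, read by crystal violet staining, with a stated time of 96 h; a lower number here means that less compound is tolerated, a higher number that more compound is tolerated. Compound 1 gives 64000 nM, compound 2 gives 18000 nM and compound 3 gives 20000 nM. Compound 3 thus stands close to compound 2 and below compound 1, the gap to compound 1 lying beyond the scatter. Compound 4 `CC(=O)NC(=S)Nc1cccc(C(F)(F)F)c1` is still to be run in this assay. Against compound 3 it shows one change: one carbon atom in place of a group of 7 heavy atoms (7 carbon; 2 five-membered non-aromatic rings of carbon only), on a carbonyl carbon An upward step is expected, a 2.5-fold higher number from compound 3 to compound 4 (0.40 log units; beyond the scatter), because compound 1 gives 64000 nM while compound 2 gives 18000 nM and compound 3 gives 20000 nM. For compound 4 the expected value is 50000 nM, with a range of 20000 nM to 130000 nM.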

Compound 4, half-maximal cytotoxic concentration: > 100000 nM
Compound 4 was reported as a limit (the forecaster's own chance of this, stated with the estimate: 20%); middle value at least 2.0-fold (0.30 log units) from the limit.
By their numbers in this assay, from the lowest: compounds 2 and 3 (each within the scatter of the next); then compound 1. At a limit, above all of these: compound 4.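

In this assay, compound 4 stands at a limit of the assay and not at a number: the limit of > 100000 nM in this assay, at which 1 of the 4 values shown sits. On the carbonyl carbon, methyl in place of the group of 7 heavy atoms gives an at least 5.0-fold higher number from compound 3 to compound 4 (0.69 log units; beyond the scatter), the first sign that this position bears on tolerance. Acetyl in place of 2-fluorophenyl on an amide-type nitrogen gives an at least 1.5-fold higher number from compound 1 to compound 4 (0.19 log units; that floor lies within the scatter), which fixes no order between those two compounds.

Still open, on these data alone, is how the number moves with an ethyl, a longer chain or a cyclohexyl on that carbonyl carbon.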